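The compounds below may be only part of what the source reports. "The series", "measured", "known", "first", "only" and "open" are said of these compounds alone.

Measured so far in a physicochemical assay for solubility; a lower number here means a less soluble compound, a higher number a more soluble compound:
compound 1 `CNC(=O)c1cc(C(=O)N[C@H]2[C@@H]3COC[C@@H]32)cc2c1OC[C@H]2c1cccnc1` — >= 104 ug/mL
compound 2 `CNC(=O)c1cc(C(=O)N[C@H]2C[C@@H]2C)cc2c1OC[C@@]2(CO)c1ccccc1` — >= 229 ug/mL
compound 3 `CNC(=O)c1cc(C(=O)N[C@@H]2C[C@H]2C)cc2c1O[C@H](CF)[C@H]2c1ccccc1` — 7 ug/mL

The value of compound 1 is a limit of this assay, not a number, sitting at the limit of >= 104 ug/mL in this assay, at which 1 of the 3 values shown sits. The value of compound 2 is likewise a limit, at the limit of >= 229 ug/mL in this assay, at which 1 of the 3 values shown sits. Compound 3 is the only one of the three with a number, and it stands far below both limits. Compound 4 `CNC(=O)c1cc(C(=O)N[C@H]2[C@@H]3COC[C@@H]32)cc2c1OC[C@H]2c1ccc(F)cc1` differs from compound 1 by 4-fluorophenyl in place of pyridin-3-yl on a saturated ring carbon. Among the measured compounds shown here, no pair of measured compounds isolates this change, so no measured step guides it. In this assay a drop beyond the scatter is expected, an at least 3.4-fold lower number from compound 1 to compound 4 (0.53 log units; beyond the scatter), with compound 4 giving a number rather than a limit. Compound 4 is estimated at 30 ug/mL, with a range from 8 ug/mL to 110 ug/mL.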

Compound 4, solubility: >= 176 ug/mL
Compound 4 was reported as a limit; the forecaster's own chance of this, stated with the estimate: 20%; at least 5.8-fold (0.76 log units) between middle value and limit.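

In this assay, compound 1 and compound 4 both stand as limits, and no step can be read between them. The compounds shown leave open how far 4-fluorophenyl and pyridin-3-yl differ on the shared core.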